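Swapping a Carboxyphenyl for a Triazole on a Shared Core

A few compounds are considered here, and "the series" means these few. Any claim that something is new, unique, unknown or untested is made for them only; others in the source may bear on it.

Among the measured compounds shown here, in an in vitro assay on CHO cells for displacement of a labelled ligand from Bombesin receptor subtype-3 (Homo sapiens), read by scintillation counting, with a stated time of 2 h (a lower number here means a stronger inhibitor, a higher number a weaker inhibitor), compound 2 `CCC(C)(C)Cc1c[nH]c(CCc2ccc(-c3ccccc3C(=O)O)cc2)n1` gives 11 nM, and the only other number, compound 1 `CCC(C)(C)Cc1c[nH]c(CCc2ccc(-c3cccc(N)n3)cc2)n1` with 7.3 nM, lies within the scatter of it. For the measured compounds named here, the one measured step, a 1.5-fold higher number from compound 1 to compound 2 (0.18 log units; within the scatter), was small. Compound 3 `CCC(C)(C)Cc1c[nH]c(CCc2ccc(-n3cncn3)cc2)n1` differs from compound 2 by 1H-1,2,4-triazol-1-yl in place of 2-carboxyphenyl on an aromatic carbon. Going by the values given here, only that single step bears on this change, and it exchanged a group on the same aromatic carbon without moving the number beyond the scatter. A step of about a 1.4-fold higher number from compound 2 to compound 3 (0.13 log units; within the scatter) is therefore expected, with no clear direction. Compound 3 is estimated at 15 nM, with a likely range from 5 nM to 45 nM.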

Compound 3, half-maximal inhibitory concentration: 340 nM
Beside the measured number, compound 3's estimate is 23-fold (1.36 log units) below it; the measured number lies above the stated range.
By their numbers in this assay, from the lowest: compounds 1 and 2 (each within the scatter of the next); then compound 3.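

Replacing 2-carboxyphenyl with 1H-1,2,4-triazol-1-yl gives a 31-fold higher number from compound 2 to compound 3 (1.49 log units; beyond the scatter) in this assay and replacing 6-aminopyridin-2-yl with it gives a 47-fold higher number from compound 1 to compound 3 (1.67 log units; beyond the scatter) in the same test. This position, which held the groups of compound 1 and compound 2 within the scatter of each other, therefore does not accept every aromatic group equally. Nothing available explains this loss of strength. Still open, from the compounds shown here alone, is whether an unsubstituted phenyl ring, an imidazole ring or a simple amine on this aromatic carbon would give a number close to compound 2 or close to compound 3.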